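The compounds below may be only part of what the source reports. "The series", "measured", "known", "first", "only" and "open" are said of these compounds alone.

Measured in a functional assay on A549 cells (Homo sapiens) for inhibition, read by MTT assay, with a stated time of 72 h; a higher number here means a weaker inhibitor, a lower number a stronger inhibitor:

- compound 1 `O=[N+]([O-])c1ccc(-c2nnc(SCCCN3CCN(c4nc5ccccc5o4)CC3)o2)cc1`: 90800 nM
- compound 2 `Cc1ccc(-c2nnc(SCCCN3CCN(c4nc5ccccc5o4)CC3)o2)cc1`: 106000 nM
- compound 3 `Clc1ccc(-c2nnc(SCCCN3CCN(c4nc5ccccc5o4)CC3)o2)cc1`: 127000 nM

These three compounds share one core and differ only in a single group on the aromatic ring. Compound 3, at 127000 nM, cannot be told apart from the other two. Its nearest neighbour is reached by a 1.2-fold higher number from compound 2 to compound 3 (0.08 log units; within the scatter), and its furthest by a 1.4-fold higher number from compound 1 to compound 3 (0.15 log units; within the scatter).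

The next compound, compound 4 `Brc1ccc(-c2nnc(SCCCN3CCN(c4nc5ccccc5o4)CC3)o2)cc1`, changes that same group: bromo in place of chloro on an aromatic carbon. In words, this is bromo in place of chloro on an aromatic carbon, or 4-chlorophenyl to 4-bromophenyl.

Among the compounds with values here, no bromo compound has been measured yet, so the nearest guide is the other swaps at this position. Besides the two steps above, there is a 1.2-fold higher number from compound 1 to compound 2 (0.07 log units; within the scatter). All three stay within the scatter, even though nitro, methyl and chloro are quite different groups. Swapping one halogen for another therefore gives no reason to expect a real shift in either direction in this assay.

The expected change is a 1.1-fold lower number from compound 3 to compound 4 (0.04 log units; within the scatter), which would be no real change. Compound 4 is estimated at 115000 nM, with an expected range from 65000 nM to 200000 nM.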

Compound 4, half-maximal inhibitory concentration: 123000 nM
For compound 4 the middle estimate is 1.1-fold (0.03 log units) below the measured one; measured number inside the range.
By their numbers in this assay, from the lowest: compounds 1, 2, 4 and 3 (each within the scatter of the next).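

In this assay, bromo in place of chloro gives a 1.0-fold lower number from compound 3 to compound 4 (0.01 log units; within the scatter) and adds a fourth group to a position where no swap has yet moved the number beyond the scatter. Compound 4 also stays close to the two compounds that carry no halogen, with a 1.2-fold higher number from compound 2 to compound 4 (0.06 log units; within the scatter) for the swap from methyl and a 1.4-fold higher number from compound 1 to compound 4 (0.13 log units; within the scatter) for the swap from nitro, so the numbers for all four groups on this aromatic carbon, para to a large group, cannot be told apart. No measurement that bears on the reason for this flat picture is available.

The four compounds leave open whether an amine, a carboxylic acid or a hydroxyl group on this same carbon would shift the number beyond the scatter, or whether this position simply has little say in this assay. They also leave open what a longer chain in place of the one in the shared core would do, since every compound shown carries that part unchanged.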